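The compounds below may be only part of what the source reports. "The series", "measured", "known", "first", "only" and "open" are said of these compounds alone.

In a functional assay on the whole organism with Cavia porcellus as the target, with a stated time of 1 h (a higher number here means that more compound is needed for the effect, a lower number that less compound is needed), compound 1 `COc1cc(C(=O)NS(=O)(=O)c2ccccc2C)ccc1Cc1cn(C=O)c2ccc(NC(=O)OC3CCCC3)cc12` gives 0.84 mg/kg and compound 2 `CCN(CC)C(=O)n1cc(Cc2ccc(C(=O)NS(=O)(=O)c3ccccc3C)cc2OC)c2cc(NC(=O)OC3CCCC3)ccc21` gives 1.2 mg/kg as the dose for half-maximal effect, so these two values lie within the scatter of each other. Compound 3 `COc1cc(C(=O)NS(=O)(=O)c2ccccc2C)ccc1Cc1cn(C(=O)NCCCc2ccccc2)c2ccc(NC(=O)OC3CCCC3)cc12` has the core of compound 2 and still awaits its measurement. The structural change is (3-phenylpropyl)amino in place of diethylamino on a carbonyl carbon. Within the data shown here, only one measured step bears on this place, namely diethylamino in place of hydrogen on a carbonyl carbon, which gave a 1.4-fold higher number from compound 1 to compound 2 (0.15 log units; within the scatter) as its result. Among the measured compounds shown here, no measured compound carries the six-membered aromatic ring or the hydrogen-bond donor that enter here, so this guide is limited. With that single step as the basis, no step beyond the scatter is expected in this assay in either direction, although the uncertainty is wide. The estimate amounts to a 1.2-fold lower number from compound 2 to compound 3 (0.08 log units; within the scatter) as the expected step. Compound 3 is expected to give 1 mg/kg (estimated range 0.3 mg/kg to 3.5 mg/kg).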

Compound 3, dose for half-maximal effect: 1.6 mg/kg
Compound 3: the middle estimate sits 1.6-fold (0.20 log units) below what was measured, and the stated range covers the measured number.
By their numbers in this assay, from the lowest: compounds 1, 2 and 3 (each within the scatter of the next).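

In this assay, (3-phenylpropyl)amino in place of diethylamino on this carbonyl carbon, whose other neighbour is an aromatic nitrogen, brings in a six-membered aromatic ring of carbon only and a hydrogen-bond donor, and the outcome is a 1.3-fold higher number from compound 2 to compound 3 (0.12 log units; within the scatter), so these additions do not separate the two compounds in this assay. Set against hydrogen on the same carbonyl carbon, the same group gives a 1.9-fold higher number from compound 1 to compound 3 (0.28 log units; within the scatter), which places hydrogen, diethylamino and (3-phenylpropyl)amino all within the scatter of one another, across a wider range of groups at this position than the first two compounds covered. Nothing in the available data explains why the three compounds lie so close together.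

The compounds shown leave open whether a carboxylic acid or an amine at the end of the propyl chain, or a longer chain in its place, would also remain within the scatter. They also do not separate the ring from the hydrogen-bond donor, which a methyl group on the nitrogen of (3-phenylpropyl)amino could begin to address.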